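The source may hold more compounds than are shown below. What is called first, only, known or untested is meant among the compounds shown, and "the series" means these compounds.

Measured compounds:
- compound 1, `Cc1cc(NC(=O)Cn2nnc(-c3ccccc3)n2)n(C2CCCCC2)n1`, in an assay on HEK293 cells for activation of Kir3.1/Kir3.2 (Homo sapiens), read by thallium flux; a lower number here means that less compound is needed, a higher number that more compound is needed for the effect: 96 nM
- compound 2, `O=C(Cn1nnc(-c2ccccc2)n1)Nc1cc(C2(C(F)(F)F)CC2)nn1C1CCCCC1`, in this assay: "not active" (no number reported)
- compound 3, `Cc1cc(NC(=O)Cn2nnc(-c3ccccc3)n2)n(-c2ccccc2)n1`, in this assay: 3020 nM

Compound 1 gives the lowest of the two numbers reported in this assay. Among the measured compounds shown here, its nearest neighbour is compound 3, and the step of a 31-fold higher number from compound 1 to compound 3 (1.50 log units; beyond the scatter) is the only one-point change among the measured compounds. Compound 2 is reported without a number, so it cannot be placed on the same scale.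

Compound 4, `Cc1cc(NC(=O)Cn2nnc(-c3ccnc(F)c3)n2)n(C2CCCCC2)n1`, differs from compound 1 in one place: 2-fluoropyridin-4-yl in place of phenyl on an aromatic carbon. For the measured compounds named here, none of the measured steps touches this part of the molecule; the single known step alters the group on the aromatic nitrogen, not the ring attached to the five-membered ring with four nitrogen atoms. The data therefore give no direct guide to the size or direction of the change in this assay. With nothing pointing the other way, compound 4 is expected to stay close to compound 1, with a wide range to allow for either a modest loss or a modest gain.

The estimate for compound 4 in this assay is 200 nM, with a range from 50 nM to 800 nM. This estimate means a step of a 2.1-fold higher number from compound 1 to compound 4 (0.32 log units; beyond the scatter), expected to be within or only slightly beyond the usual scatter.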

Compound 4, half-maximal effective concentration: 441 nM
Beside the measured number, compound 4's estimate is 2.2-fold (0.34 log units) below it; low and high end bracket the measured number.
By their numbers in this assay, from the lowest: compound 1; then compound 4; then compound 3.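

In this assay, among the compounds shown here, a 4.6-fold higher number from compound 1 to compound 4 (0.66 log units; beyond the scatter) is the first measured step at the aromatic carbon of the five-membered ring with four nitrogen atoms. It shows that this position responds to a change of ring: replacing phenyl with 2-fluoropyridin-4-yl means more compound is needed for the effect, a step beyond the usual scatter. The ring can still be altered without losing a measurable number, although nothing here explains the rise, as no supporting measurement bears on it.

The swap brings in a ring nitrogen and a fluorine together, so this single step cannot show how much each contributes, and a plain pyridine ring or a phenyl ring carrying only fluorine would be needed to separate the two. Going by these compounds, it also remains open whether any replacement at this position can match or improve on phenyl in compound 1, for example a phenyl ring bearing a methoxy group, an amine or a carboxylic acid, or a different ring such as thiophene.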